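Working notes: 3-fluorophenyl to 4-fluorophenyl on sulfur

A few compounds are considered here, and "the series" means these few. Any claim that something is new, unique, unknown or untested is made for them only; others in the source may bear on it.

- compound 1 `Nc1ccccc1NC(=O)c1ccc(CSc2cccc(F)c2)cc1`: 3280 nM
- compound 2 `Nc1ccccc1NC(=O)c1ccc(CSc2nccc(C(F)(F)F)n2)cc1`: 1890 nM
- compound 3 `Nc1ccccc1NC(=O)/C=C/c1ccc(CSCCc2ccccc2)cc1`: 10900 nM

These values come from a functional assay on SMMC-7721 cells (Homo sapiens) for antiproliferative activity, read by CCK-8 assay, with a stated time of 72 h; a higher number here means a weaker inhibitor, a lower number a stronger inhibitor. Compound 1 cannot be told apart from compound 2 within the scatter, while compound 3 carries a higher number, beyond the scatter. The next compound to be measured is compound 4 `Nc1ccccc1NC(=O)c1ccc(CSc2ccc(F)cc2)cc1`, which has 4-fluorophenyl in place of 3-fluorophenyl on a sulfur. For the measured compounds named here, no pair of measured compounds differs in one place only, so the series gives no direct measure of a change of this kind. The nearest guide is indirect: compound 2 (1890 nM) has a different group on the sulfur and still sits within the scatter of compound 1 (3280 nM). No step beyond the scatter is therefore expected in this assay, and no firm direction can be assigned. The expected change is small, an estimated 1.2-fold lower number from compound 1 to compound 4 (0.07 log units; within the scatter) in all. The estimated value for compound 4 is 2800 nM, with an expected range from 1200 nM to 6500 nM on repeat measurement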

Compound 4, half-maximal inhibitory concentration: 5770 nM
Compound 4: the middle estimate sits 2.1-fold (0.31 log units) below what was measured, and the stated range covers the measured number.
By their numbers in this assay, from the lowest: compounds 2, 1, 4 and 3 (each within the scatter of the next, the first and the last beyond it).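

In this assay the series now has its first direct one-place comparison, with a 1.8-fold higher number from compound 1 to compound 4 (0.25 log units; within the scatter) for 4-fluorophenyl in place of 3-fluorophenyl on a sulfur. On this position, then, changing only where the fluorine sits on the phenyl ring, with the heavy atoms and ring type unchanged, does not separate the two compounds beyond the scatter. The data shown offer no measured basis for explaining this small step.

From the compounds shown here alone, what remains open is whether phenyl without fluorine, 4-chlorophenyl or 4-methoxyphenyl on the same sulfur would give a step beyond the scatter from compound 1. The compounds shown also leave open whether a longer chain between the sulfur and the ring would do so.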